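Swapping Acetyl for Dimethylamino on a Pyrazole Series

This account rests on a few compounds, and the source may have more. Where it says the series, first, only, none or still open, it means among the compounds named here.

Measured compounds:
Compound 1 `COc1cc(C)cc(-c2c(-c3ccnc(-c4ccc(C(C)=O)cc4)c3)cnn2CC#N)c1` — 82%
Compound 2 `Cc1cc(O)cc(-c2nn(CC#N)cc2-c2ccnc(-c3ccc(Oc4ccccc4)cc3)c2)c1` — 84%

Of the compounds shown here, two have been tested in a functional assay on BT-549 cells (Homo sapiens) for cytotoxicity, read by sulforhodamine B assay, with a stated time of 48 h, tested at 100 nM; on this read-out higher numbers stand for a weaker effect at the one concentration tested and lower numbers for a stronger effect. Compound 1 gives 82% in this assay, and compound 2 gives 84%. The two numbers lie within the scatter of each other, so neither can be set apart from the other on the present data; compound 1 simply stands alongside compound 2 at a level that reflects a weak effect at the single concentration tested.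

Compound 3 `COc1cc(C)cc(-c2c(-c3ccnc(-c4ccc(N(C)C)cc4)c3)cnn2CC#N)c1` has not yet been measured. Its difference from compound 1 is dimethylamino in place of acetyl on an aromatic carbon. Going by the values given here, no step between measured compounds describes this kind of change, so there is no measured precedent to lean on. Given that both compounds 1 and 2 sit at a similar level in this assay, the change from compound 1 to compound 3 is expected to produce no step beyond the scatter, as a number 2 percentage points higher from compound 1 to compound 3 (within the scatter). Compound 3 is therefore expected to give about 84%, with a range from 68% to 100%.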

Compound 3, a percentage reported as activity, at one concentration (the size of the read-out at that concentration, not a potency): -18%
The estimate for compound 3 lay 102 percentage points above the measured number, outside the stated range (below it).
By their numbers in this assay, from the lowest: compound 3; then compounds 1 and 2 (each within the scatter of the next).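

The change from 4-acetylphenyl to 4-(dimethylamino)phenyl shows that this place, on an aromatic carbon para to a large group, can strongly move the read-out in this assay: the step is a number 100 percentage points lower from compound 1 to compound 3 (beyond the scatter) and gives the series its first difference beyond the scatter. The leaving and entering groups have the same count of heavy atoms and of hydrogen-bond acceptors, and neither carries a net charge, so these counts do not separate acetyl from dimethylamino. The data offer no measured explanation for the size of this step.

As far as these compounds go, it remains open whether the effect needs both methyl groups of dimethylamino, or whether a primary amine, a morpholine ring or a methoxy group at the same place would give a similar result. A read-out at one concentration also shows only the stronger effect of compound 3 at that concentration.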